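Phenyl for amino on the fused aromatic ring

A few compounds are considered here, and "the series" means these few. Any claim that something is new, unique, unknown or untested is made for them only; others in the source may bear on it.

In an assay on membranes from Cerebral cortex for displacement of a labelled ligand from Neuronal acetylcholine receptor; alpha4/beta2 (Rattus norvegicus), with a stated time of 5 min (a higher number here means a weaker inhibitor, a lower number a stronger inhibitor), compound 2 `CN1CCC[C@H]1[C@H]1COc2c(N)cccc2O1` gives 131 nM, the lowest of the three numbers; compound 1 `CN1CCC[C@H]1[C@H]1COc2ccc(N)cc2O1` gives 140 nM, within the scatter of compound 2, and compound 3 `CN1CCC[C@H]1[C@@H]1COc2c(N)cccc2O1` gives 7100 nM. Within the data shown here, the only single-point step among them, a 54-fold higher number from compound 2 to compound 3 (1.73 log units; beyond the scatter), is large, and it rests on (the fact that compounds 2 and 3 differ only in the configuration as drawn). Compound 4 `CN1CCC[C@H]1[C@H]1COc2c(cccc2-c2ccccc2)O1` differs from compound 2 by phenyl in place of amino on an aromatic carbon. Among the measured compounds shown here, no measured step alters a group on the aromatic ring, so the stereochemical step offers no direct guide to this change; the amino group leaves and a phenyl enters, as counted. The expectation for compound 4 is a moderate rise in this assay, a 5.3-fold higher number from compound 2 to compound 4 (0.73 log units; beyond the scatter). Compound 4 is estimated at 700 nM, with a range from 100 nM to 5000 nM.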

Compound 4, inhibition constant: 7300 nM
The estimate for compound 4 lay 10-fold (1.02 log units) below the measured number; the measured number lies above the stated range.
By their numbers in this assay, from the lowest: compounds 2 and 1 (each within the scatter of the next); then compounds 3 and 4 (each within the scatter of the next).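

Among the earlier compounds, only a change of configuration gave a step; the group on the aromatic carbon now matters as well. In this assay, phenyl in place of amino gives a 56-fold higher number from compound 2 to compound 4 (1.75 log units; beyond the scatter), so this position does not accept every group equally. Nothing measured gives a cause for this step.

The step cannot separate the loss of amino from the entry of phenyl. On these data alone, whether a small group such as methyl, hydroxyl or methoxy on this carbon would hold the number of compound 2 remains open.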